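Swapping the carboxy group for fluorine on the anilide ring

The source may report more compounds than this note shows. Statements on the series, on what has been measured and on what is new or still open speak of the compounds shown alone.

Of the compounds shown here, three sharing one core have been measured in an assay on cells for activation of Cystic fibrosis transmembrane conductance regulator (Homo sapiens), read by fluorescence, with stated times of 10 min and 12 s; on this read-out lower numbers stand for an effect already at smaller amounts and higher numbers for an effect only at larger amounts of compound. Compound 1 `CCN(CC)c1nc(Nc2cccc(C(=O)O)c2)nc(OCC(F)(F)C(F)F)n1` gives 500 nM. Compound 2 `CCN(CC)c1nc(Nc2cccc([N+](=O)[O-])c2)nc(OCC(F)(F)C(F)F)n1` gives 1200 nM, and compound 3 `CCN(CC)c1nc(Nc2ccc(C(=O)O)cc2)nc(OCC(F)(F)C(F)F)n1` gives 2500 nM. Among these three, compound 3 has the highest number: the steps of a 5.0-fold higher number from compound 1 to compound 3 (0.70 log units; beyond the scatter) and a 2.1-fold higher number from compound 2 to compound 3 (0.32 log units; beyond the scatter) both lie beyond the scatter, so it is the weakest of the measured set.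

Compound 4 `CCN(CC)c1nc(Nc2ccc(F)cc2)nc(OCC(F)(F)C(F)F)n1` has not yet been measured. It differs from compound 3 in one place: fluoro in place of carboxy on an aromatic carbon.

Among the measured compounds shown here, no measured step swaps carboxy for fluoro directly. The step that comes closest is a 2.4-fold higher number from compound 1 to compound 2 (0.38 log units; beyond the scatter), where the carboxy group was also removed and another group took its place; the number rose modestly. The two carboxy-bearing compounds also differ by a 5.0-fold higher number from compound 1 to compound 3 (0.70 log units; beyond the scatter), which shows that the ring position matters, but that step says nothing about what happens once the carboxy group is gone.

On this basis a modest rise in the number is expected for compound 4, with a 2.4-fold higher number from compound 3 to compound 4 (0.38 log units; beyond the scatter) as the expected step from compound 3. For compound 4 the estimate in this assay is 6000 nM, with a range from 2000 nM to 20000 nM.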

Compound 4, half-maximal effective concentration: 4800 nM
Compound 4: middle estimate off by 1.3-fold (0.10 log units), on the high side, and the stated range covers the measured number.
By their numbers in this assay, from the lowest: compound 1; then compound 2; then compounds 3 and 4 (each within the scatter of the next).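

On the ring carbon para to a large group, the carboxy group and the fluoro group cannot be told apart by their numbers (a 1.9-fold higher number from compound 3 to compound 4 (0.28 log units; within the scatter)), a step within the usual scatter. The carboxy group counts one hydrogen-bond donor and one hydrogen-bond acceptor and the fluoro group counts neither, so in this pair those counts go with no change beyond the scatter, whereas the earlier swap of carboxy for nitro in the 3-substituted compounds gave a step beyond it. The clearer gaps appear when the 4-fluorophenyl group replaces a 3-substituted ring, both against the 3-nitrophenyl compound (a 4.0-fold higher number from compound 2 to compound 4 (0.60 log units; beyond the scatter)) and, by a larger step, against the 3-carboxyphenyl compound (a 9.6-fold higher number from compound 1 to compound 4 (0.98 log units; beyond the scatter)), although each of these steps changes the group and its ring position together.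

On these data alone, it remains open whether a fluoro group on the ring position that carries the carboxy group in compound 1 would match that compound, and how an amine or a longer carbon chain would fare at either ring position. Nothing available here explains any of these steps.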